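Adding one methyl to compound 1

The source may hold more compounds than are shown below. What is called first, only, known or untested is meant among the compounds shown, and "the series" means these compounds.

Measured in a functional assay on HCT-15 cells (Homo sapiens) for inhibition; on this read-out lower numbers stand for stronger inhibition and higher numbers for weaker inhibition:
Compound 1 `COc1cc(-n2cncc2-c2ccc3[nH]ccc3c2)cc(OC)c1OC` gives 350 nM
Compound 2 `COc1cc(-c2ncoc2-c2ccc3c(ccn3C)c2)cc(OC)c1OC` gives 7.4 nM

Of these two compounds, compound 1 has the higher number and so the weaker inhibition, and its gap to compound 2 lies beyond the usual scatter of repeated measurements. The next compound, compound 3 `COc1cc(-n2cncc2-c2ccc3c(ccn3C)c2)cc(OC)c1OC` but not yet measured, comes from compound 1 by a single edit: methyl in place of hydrogen on an aromatic nitrogen.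

Going by the values given here, no measured pair shows this edit alone, so its size can only be judged indirectly. Among the compounds with values here, the one hint comes from compound 2 (7.4 nM), which carries the same methyl but differs from compound 3 elsewhere in the core. A lower number is therefore expected in this assay, probably beyond the scatter, though not necessarily reaching compound 2. The estimated change is a 7.0-fold lower number from compound 1 to compound 3 (0.85 log units; beyond the scatter) in the direction of stronger inhibition. Compound 3 is expected at 50 nM with 10 nM to 250 nM as the estimated range.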

Compound 3, half-maximal inhibitory concentration: 14 nM
Compound 3: middle estimate off by 3.6-fold (0.55 log units), on the high side, and the stated range covers the measured number.
By their numbers in this assay, from the lowest: compounds 2 and 3 (each within the scatter of the next); then compound 1.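

Replacing the hydrogen on the aromatic nitrogen with methyl gives, in this assay, a 25-fold lower number from compound 1 to compound 3 (1.40 log units; beyond the scatter) and so a large move toward stronger inhibition. Compound 1 and compound 2 differ in more than one place, so their gap could not be credited to the methyl, whereas this pair isolates that single carbon and shows that this one position alone can change the result by a wide margin; in this core, the hydrogen on that nitrogen is also not needed for strong inhibition on these cells. Nothing available explains how the methyl produces this gain.

The compounds shown leave open whether an ethyl group, or a longer chain ending in an amine, on the same nitrogen would keep this inhibition, so it is unclear whether the gain belongs to methyl in particular or to replacing the hydrogen with any carbon group. Also open, going by these compounds, is whether the edit would have a similar size in the core of compound 2, as only the methylated form of that core appears here.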